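The compounds below may be only part of what the source reports. "The series", "measured", "known", "first", "only" and "open" are said of these compounds alone.

Working notes on the series. In a functional assay on PC-12 cells (Rattus norvegicus) for cytotoxicity, read by MTT assay, with a stated time of 24 h (a higher number here means a weaker inhibitor, a lower number a stronger inhibitor), compound 2 `CC(=O)O[C@@]1(C)CCC(=O)[C@H](C)CCC[C@]2(C)O[C@H]2C(=O)C(=C(C)C)CC1` gives 43800 nM. Compound 1 `CC(=O)O[C@@]1(C)C/C=C2\O[C@H](C[C@@H]2C)C[C@]2(C)O[C@H]2C(=O)C(=C(C)C)CC1` gives 41100 nM, which is within the scatter of compound 2, so the two stand level. Compound 3 `CC(C)=C1CC[C@]2(C)CC[C@]3(O[C@H](C[C@H]3C)C[C@]3(C)O[C@H]3C1=O)O2` returns only a limit of the assay, > 50000 nM.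

Compound 4 `CC(=O)O[C@@]1(C)CCC(=O)[C@@H](C)CCC[C@]2(C)O[C@H]2C(=O)C(=C(C)C)CC1` is still to be measured in this assay. Its difference from compound 2 is the two compounds have the same atoms and bonds and differ only in configuration as drawn: 1 of 4 stereo elements differ; a stereocentre at a saturated ring carbon is drawn R in compound 2 and S in compound 4: the two compounds have the same atoms and bonds, and a stereocentre at a saturated ring carbon is drawn R in compound 2 and S in compound 4. Within the data shown here, no measured pair isolates a change of configuration, so the size of such a step cannot be read directly. The expectation rests on compound 2 at 43800 nM, and no direction is favoured. The estimated step of a 1.0-fold lower number from compound 2 to compound 4 (0.02 log units; within the scatter) is expected to stay within the scatter. For compound 4 the expected value is 42000 nM, with an estimated range of 25000 nM to 50000 nM.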

Compound 4, half-maximal inhibitory concentration: 24500 nM
Estimate against measurement, compound 4: 1.7-fold (0.23 log units) above; the whole stated range lies above it.
By their numbers in this assay, from the lowest: compounds 4, 1 and 2 (each within the scatter of the next). At a limit, above all of these: compound 3.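

In this assay, the series now holds its first step that isolates a change of configuration, at a stereocentre on a saturated ring carbon: a 1.8-fold lower number from compound 2 to compound 4 (0.25 log units; within the scatter). The size of this step does not go beyond the scatter, so this inversion gives no evidence of a real difference in this read-out. The reading can be assigned to configuration alone, because no other structural change accompanies it: the fact that compounds 2 and 4 differ only in the configuration as drawn.

Still open, going by these compounds, is whether changing configuration at any of the other stereo elements, or adding an amine or a carboxylic acid to the shared core, would give a step beyond the scatter. Among these compounds, for compound 3, > 50000 nM is a limit of the assay and not a number, so it gives no step.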